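The compounds below may be only part of what the source reports. "The series", "measured", "known", "first", "only" and "open" are said of these compounds alone.

In a functional assay on UO-31 cells (Homo sapiens) for inhibition, read by sulforhodamine B assay, with a stated time of 48 h (on this read-out higher numbers stand for lower toxicity in this test and lower numbers for higher toxicity in this test), compound 2, `COc1ccc(C(=O)/C=C/c2cc(-c3cc(OC)c(OC)c(OC)c3)n[nH]2)cc1`, gives 5590 nM. Within the data shown here, this is the only plain number in the set. Compound 1, `COc1cc(-c2cc(/C=C/C(=O)c3ccc(Cl)c(Cl)c3)[nH]n2)cc(OC)c1OC`, differs from compound 2 only in the group on the carbonyl carbon, a 3,4-dichlorophenyl instead of a 4-methoxyphenyl. For compound 1 this assay reports only a limit, > 100000 nM. Among the measured compounds shown here, the one measured step, an at least 17-fold lower number from compound 1 to compound 2 (1.25 log units; beyond the scatter), is therefore large but open-ended, and it rests on (the limit of > 100000 nM in this assay, at which 1 of the 2 values shown sits).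

Compound 3, `COc1cc(-c2cc(/C=C/C(=O)c3ccc(F)c(F)c3)[nH]n2)cc(OC)c1OC`, has not yet been measured in this assay. It differs from compound 2 as follows: 3,4-difluorophenyl in place of 4-methoxyphenyl on a carbonyl carbon. The change swaps the group that gave compound 2 its lower number back toward a dihalogenated ring, now carrying fluorine rather than chlorine, so it runs opposite to the measured step. A rise in the number is expected, though the fluorine ring is not the chlorine ring, so the full size of that step need not return. The expected change from compound 2 is a 5.4-fold higher number from compound 2 to compound 3 (0.73 log units; beyond the scatter). Compound 3 is estimated at 30000 nM, with a likely range from 8000 nM to 150000 nM, and a fair chance that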

Compound 3, concentration lethal to 50% of the cells: > 100000 nM
Compound 3: only a limit was reported (the forecaster's own chance of this, stated with the estimate: 35%); middle value at least 3.3-fold (0.52 log units) away from the limit.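

In this assay, replacing the 4-methoxyphenyl on the carbonyl carbon with 3,4-difluorophenyl gives an at least 17-fold higher number from compound 2 to compound 3 (1.25 log units; beyond the scatter), so the large difference first seen with the 3,4-dichlorophenyl ring also appears with a second dihalogenated ring and among the compounds shown is not tied to chlorine alone. Compound 3 gives > 100000 nM, which is a limit of the assay and not a number. The step from compound 1 to compound 3 cannot be read, so these results do not separate the fluorine ring from the chlorine ring, and the true size of both steps from compound 2 stays open-ended: the limit of > 100000 nM in this assay, at which 2 of the 3 values shown sit.

Among these compounds, with compound 2 as the only one of the three compounds with a plain number, it remains open whether the lower number depends on the methoxy group itself or simply on the absence of halogens from the ring. A plain phenyl ring, or a phenyl ring carrying a hydroxyl or a dimethylamino group, on the same carbonyl carbon would help to tell these two readings apart.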